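Imine aryl variation on the shared core

The source may hold more compounds than are shown below. What is called first, only, known or untested is meant among the compounds shown, and "the series" means these compounds.

Measured so far:
Compound 1 `CCCCc1oc2ccc(/N=C/c3ccc(F)cc3)cc2c1C(=O)c1ccc(OC)cc1` gives 100 ug/mL in a functional assay, with a stated time of 30 min; a higher number here means a weaker inhibitor, a lower number a stronger inhibitor.
Compound 2 `CCCCc1oc2ccc(/N=C/c3ccc(Cl)cc3Cl)cc2c1C(=O)c1ccc(OC)cc1` gives 2.44 ug/mL in this assay.

For the measured compounds named here, compound 2 holds the lowest of the two numbers; its only neighbour is compound 1, separated by a 41-fold lower number from compound 1 to compound 2 (1.61 log units; beyond the scatter). Compound 3 `CCCCc1oc2ccc(/N=C/c3ccc(O)cc3O)cc2c1C(=O)c1ccc(OC)cc1` carries the change (2,4-dihydroxyphenyl in place of 2,4-dichlorophenyl on a carbon with a double bond to nitrogen). Going by the values given here, the one measured step, a 41-fold lower number from compound 1 to compound 2 (1.61 log units; beyond the scatter), alters the same ring and was large, so this ring clearly moves the number, but no measured compound carries hydroxyl groups there, and the direction is uncertain. Compound 3 is expected at 20 ug/mL, range 3 ug/mL to 100 ug/mL. That estimate means an expected step of an 8.2-fold higher number from compound 2 to compound 3 (0.91 log units; beyond the scatter).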

Compound 3, half-maximal inhibitory concentration: 7.55 ug/mL
Compound 3: the middle estimate sits 2.6-fold (0.42 log units) above what was measured; measured number inside the range.
By their numbers in this assay, from the lowest: compound 2; then compound 3; then compound 1.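

Hydroxyl groups can replace the chlorines at this position with only part of the gain lost: the change costs little (a 3.1-fold higher number from compound 2 to compound 3 (0.49 log units; beyond the scatter)), while the distance from the 4-fluorophenyl compound stays wide (a 13-fold lower number from compound 1 to compound 3 (1.12 log units; beyond the scatter)). A low number here is therefore not tied to 2,4-dichlorophenyl, and both 2,4-disubstituted rings sit below 4-fluorophenyl in the three compounds shown. No measurement available here explains this difference.

From the compounds shown here alone, whether the second substituent or its identity matters remains open. A 4-chlorophenyl or 2,4-dimethoxyphenyl group would help separate these possibilities.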